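Three weak inhibitors and a new amine substituent

This account rests on a few compounds, and the source may have more. Where it says the series, first, only, none or still open, it means among the compounds named here.

Measured compounds:
compound 1 `NC(=O)c1c(NC(=O)c2ccccc2Cl)sc2c1CCN(Cc1ccc(Cl)cc1)C2` with 22500 nM
compound 2 `Cc1ccc(C(=O)Nc2sc3c(c2C(N)=O)CCN(Cc2ccc(Cl)cc2Cl)C3)cc1` with 19900 nM
compound 3 `NC(=O)c1c(NC(=O)c2cccc([N+](=O)[O-])c2)sc2c1CCN(Cc1c(Cl)cccc1Cl)C2` with 18400 nM

All three were tested in a functional assay on HL-60 cells (Homo sapiens) for antiproliferative activity, with a stated time of 24 h; a higher number here means a weaker inhibitor, a lower number a stronger inhibitor. Compound 1 has the highest of the three numbers, but its nearest neighbour compound 2 and its furthest neighbour compound 3 both sit within the scatter of repeated measurements, so the three compounds cannot be told apart on these data; all three are weak inhibitors of HL-60 cell growth.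

Compound 4 `COc1ccc(NC(=S)N2CCc3c(sc(NC(=O)c4ccccc4Cl)c3C(N)=O)C2)cc1` has not yet been measured. Relative to compound 1 it differs in one place: a group of 11 heavy atoms (8 carbon, 1 nitrogen, 1 oxygen, 1 sulfur; one six-membered aromatic ring of carbon only) in place of a group of 8 heavy atoms (7 carbon, 1 chlorine; one six-membered aromatic ring of carbon only), on an amine nitrogen in a ring. The 4-chlorobenzyl group on the amine nitrogen in the ring is thus replaced by a larger group that brings one hydrogen-bond donor and two hydrogen-bond acceptors to the same position.

Among the measured compounds shown here, no pair of measured compounds differs in a single place, so no measured step shows what a change at this position does. The three measured values lie close together despite different substituents at this amine nitrogen and on the amide, which gives no reason to expect a large effect. The step from compound 1 to compound 4 is therefore expected to be a 1.1-fold lower number from compound 1 to compound 4 (0.05 log units; within the scatter), within the scatter. For compound 4 the estimate in this assay is 20000 nM, with a range from 7000 nM to 60000 nM.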

Compound 4, half-maximal inhibitory concentration: 15700 nM
Compound 4: the middle estimate sits 1.3-fold (0.11 log units) above what was measured; measured number inside the range.
By their numbers in this assay, from the lowest: compounds 4, 3, 2 and 1 (each within the scatter of the next).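

Among the compounds shown here, compound 1 and compound 4 give the first comparison in which only the group on the amine nitrogen in the ring differs. In this assay, replacing the 4-chlorobenzyl group with the larger group, which brings a sulfur, a hydrogen-bond donor and hydrogen-bond acceptors, gives a 1.4-fold lower number from compound 1 to compound 4 (0.16 log units; within the scatter), so this position accepts quite a different group without a change that can be told from the scatter, and the two compounds remain equally weak inhibitors of cell growth. No measurement shown gives a reason for this outcome, which rests on a single step at this position and one amide partner, the one with the 2-chlorobenzoyl-type ring of compound 1 and compound 4.

The compounds shown leave open whether any group at this amine nitrogen can move the number beyond the scatter, for example a free ring amine with only hydrogen there, a small methyl, or a longer chain ending in a carboxylic acid or an amine. They also leave open whether the same swap would behave alike with the amide groups of compound 2 and compound 3, since neither of those forms a single-place pair with compound 4.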